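The compounds below may be only part of what the source reports. "The series", "measured", "known", "first", "only" and "open" are said of these compounds alone.

Measured so far in a functional assay on a cell-free system (plasma, Oryctolagus cuniculus) for inhibition, with stated times of 5 min, 1 min and 6 min; a higher number here means a weaker inhibitor, a lower number a stronger inhibitor:
compound 1, `CCOC(=O)c1c(C)nc(-c2cccc(C#N)c2)n1O`, gives 17600 nM.
compound 2, `CCOC(=O)c1c(C)nc(-c2cccc(C#N)c2)n1OC(C)C`, gives 6740 nM.
compound 3, `CCOC(=O)c1c(C)nc(-c2cccc(C#N)c2)n1OCC(N)=O`, gives only a limit of the assay, > 30000 nM.

Compound 1 stands with the highest of the two numbers shown in this assay; its nearest neighbour is compound 2, reached by a 2.6-fold lower number from compound 1 to compound 2 (0.42 log units; beyond the scatter). Compound 3 sits at a limit and not a number, (the limit of > 30000 nM in this assay, at which 1 of the 3 values shown sits). Its step from compound 1 reads an at least 1.7-fold higher number from compound 1 to compound 3 (0.23 log units; that floor lies within the scatter), and the step from compound 2 to compound 3 reads an at least 4.4-fold higher number from compound 2 to compound 3 (0.64 log units; beyond the scatter).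

Compound 4, `CCOC(=O)c1c(C)nc(-c2cccc(C#N)c2)n1OCc1ccc(C)cc1`, is not yet measured. It differs from compound 1 by 4-methylbenzyl in place of hydrogen on an oxygen on an aromatic ring. The step from compound 1 to compound 2 is the one that bears on it: a carbon group placed on the same oxygen, giving a modest downward step. The carbamoylmethyl step went the other way, but 4-methylbenzyl, like isopropyl, is a carbon-only group. Compound 4 is therefore expected to give a modestly lower number than compound 1, a 3.5-fold lower number from compound 1 to compound 4 (0.55 log units; beyond the scatter), estimated at 5000 nM with a range from 1500 nM to 20000 nM.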

Compound 4, half-maximal inhibitory concentration: 6310 nM
Compound 4: the middle estimate sits 1.3-fold (0.10 log units) below what was measured, within the range that was stated.
By their numbers in this assay, from the lowest: compounds 4 and 2 (each within the scatter of the next); then compound 1. At a limit, above all of these: compound 3.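

In this assay, a second carbon-only group on this oxygen moves the number the same way as isopropyl did, with a 2.8-fold lower number from compound 1 to compound 4 (0.45 log units; beyond the scatter), while 4-methylbenzyl and isopropyl cannot be told apart, with a 1.1-fold lower number from compound 2 to compound 4 (0.03 log units; within the scatter), so the six-membered aromatic ring shows no gain over isopropyl here. Carbamoylmethyl remains the one group on this oxygen that goes against the carbon-only pair, with an at least 4.7-fold lower number from compound 3 to compound 4 (0.67 log units; beyond the scatter). Compound 3 is held at a limit and not a number: the limit of > 30000 nM in this assay, at which 1 of the 4 values shown sits.

As far as these compounds go, whether an amine or a carboxylic acid at the end of a longer chain on this oxygen would behave like the carbon-only groups or like carbamoylmethyl stays open. Also open, from the compounds shown here alone, is whether methoxy in place of the methyl of 4-methylbenzyl would shift the number at all.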